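The source may report more compounds than this note shows. Statements on the series, on what has been measured and on what is new or still open speak of the compounds shown alone.

Measured in a functional assay on RT2 cells (Rattus norvegicus) for cytotoxicity, read by MTT assay, with a stated time of 48 h; on this read-out lower numbers stand for stronger inhibition and higher numbers for weaker inhibition:
Compound 1 `NC(=S)N/N=C(\N)c1ccccn1`: 7280 nM
Compound 2 `CCNC(=S)N/N=C(\N)c1ccccn1`: 359000 nM

Compound 2 has the higher number of the pair, 359000 nM, so it is the weaker of the two in this assay. Compound 3 `CNC(=S)N/N=C(\N)c1ccccn1` has not yet been measured. It differs from compound 2 by one change: hydrogen in place of methyl on a saturated chain carbon bound to an amide-type nitrogen. In words, this is hydrogen in place of methyl on a saturated chain carbon bound to an amide-type nitrogen, so ethyl becomes methyl. Going by the values given here, one measured step bears on this, and it is large: a 49-fold higher number from compound 1 to compound 2 (1.69 log units; beyond the scatter), with ethyl in place of hydrogen on an amide-type nitrogen. Compound 3 carries methyl where compound 1, at 7280 nM, carries hydrogen and compound 2 carries ethyl. Part of that step is therefore expected to be undone, giving a lower number but a smaller step. The expected step is an 8.0-fold lower number from compound 2 to compound 3 (0.90 log units; beyond the scatter). For compound 3 the estimated value is 45000 nM, with an expected range of 10000 nM to 200000 nM.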

Compound 3, half-maximal inhibitory concentration: 12200 nM
Beside the measured number, compound 3's estimate is 3.7-fold (0.57 log units) above it; the measured number falls inside the stated range.
By their numbers in this assay, from the lowest: compounds 1 and 3 (each within the scatter of the next); then compound 2.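

Trimming ethyl to methyl gives a 29-fold lower number from compound 2 to compound 3 (1.47 log units; beyond the scatter) in this assay and so shows that a single carbon at the end of this chain separates a large loss from almost none. Methyl in place of hydrogen on the amide-type nitrogen gives a 1.7-fold higher number from compound 1 to compound 3 (0.22 log units; within the scatter) and leaves the two compounds indistinguishable here, so the loss seen earlier with ethyl does not come from any group at all on this nitrogen, and the values do not climb evenly from hydrogen through methyl to ethyl. No measurement shown here explains why that one carbon matters so much. On these data alone, whether a longer chain such as propyl stays as weak as ethyl remains open. So does whether a ring such as phenyl, or an ethyl chain ending in a hydroxyl, would be accepted on this nitrogen.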